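Fluoro to iodo: what compound 3 may do

A few compounds are considered here, and "the series" means these few. Any claim that something is new, unique, unknown or untested is made for them only; others in the source may bear on it.

In a functional assay on MCF7 cells (Homo sapiens) for cytotoxicity, read by MTT assay, with a stated time of 48 h (on this read-out lower numbers stand for stronger inhibition and higher numbers for weaker inhibition), compound 1 (`C/C(=N/NC(=S)Nc1ccccc1F)c1ccccn1`) gives 0.39 nM. Among the measured compounds shown here, compound 2 (`C/C(=N\NC(=S)Nc1ccccc1F)c1ccccn1`) gives 0.39 nM, so compound 1 stands level with the only other compound measured. These two compounds differ only in how one double bond is drawn, and the step between them shows no change at the digits printed from compound 1 to compound 2 (within the scatter).

The next compound makes a different kind of change. Compound 3 (`C/C(=N/NC(=S)Nc1ccccc1I)c1ccccn1`) departs from compound 1 by iodo in place of fluoro on an aromatic carbon, with iodo in place of fluoro on an aromatic carbon. For the measured compounds named here, no measured step replaces the fluoro group, so the step showing no change at the digits printed from compound 1 to compound 2 (within the scatter) gives only weak guidance and no direction. The plain expectation in this assay is therefore no shift beyond the scatter, with wide uncertainty. The expected step is a 1.0-fold higher number from compound 1 to compound 3 (0.01 log units; within the scatter). For compound 3 the estimated value is 0.4 nM, with an expected range from 0.08 nM to 2 nM.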

Compound 3, half-maximal inhibitory concentration: 4.1 nM
Estimate against measurement, compound 3: 10-fold (1.01 log units) below; measured number above the stated range.
By their numbers in this assay, from the lowest: compounds 1 and 2 (each within the scatter of the next); then compound 3.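

The group at this place on the aromatic ring matters in this assay: iodo in place of fluoro on an aromatic carbon gives an 11-fold higher number from compound 1 to compound 3 (1.02 log units; beyond the scatter). The earlier pair differed only in how one double bond is drawn, so it could not show this; here, a single-atom swap on the ring weakens inhibition clearly. Among the compounds shown here, nothing given here explains why this swap moves the number so far.

Going by these compounds, it remains open whether chloro or bromo at the same place would give a number close to that of compound 1, close to that of compound 3, or somewhere in between, and whether a methyl or an amine would behave like a halogen here. On these data alone, it is also open whether the iodo compound would respond to the drawn form of the double bond.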